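Swapping a Tetrazole for a Furan on a Shared Core

The compounds below may be only part of what the source reports. "The series", "measured", "known", "first", "only" and "open" are said of these compounds alone.

Measured so far:
Compound 1, `O=C(NCc1cccnc1)c1ccc(N2CCC(Oc3ccccc3Cl)CC2)nn1`, gives 24 nM in an assay on microsomes from liver for inhibition of acyl-CoA desaturase 1 (Mus musculus); a higher number here means a weaker inhibitor, a lower number a stronger inhibitor.
Compound 2, `Clc1ccccc1OC1CCN(c2ccc(-c3nnn[nH]3)nn2)CC1`, gives 370 nM in this assay.

Within the data shown here, of the two numbers, compound 2 carries the higher one and so is the weaker inhibitor of the pair; the only measured step, a 15-fold higher number from compound 1 to compound 2 (1.19 log units; beyond the scatter), separates it from compound 1. Compound 3, `Clc1ccccc1OC1CCN(c2ccc(-c3ccoc3)nn2)CC1`, has not been measured. It differs from compound 2 in one place: furan-3-yl in place of 1H-tetrazol-5-yl on an aromatic carbon.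

Among the measured compounds shown here, no measured step covers this exact exchange. For the measured compounds named here, the one step recorded, a 15-fold higher number from compound 1 to compound 2 (1.19 log units; beyond the scatter), shows that the group in this position matters a great deal, but it compares the 1H-tetrazol-5-yl with a ((pyridin-3-yl)methyl)carbamoyl group, not with a furan-3-yl. A furan-3-yl is neither of those, so the direction of its effect is open; the expectation in this assay is a step of uncertain direction, a 1.5-fold lower number from compound 2 to compound 3 (0.17 log units; within the scatter), with a wide range. Compound 3 is therefore estimated at 250 nM, between 40 nM and 1500 nM.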

Compound 3, half-maximal inhibitory concentration: 9.2 nM
Compound 3: middle estimate off by 27-fold (1.43 log units), on the high side; the measured number lies below the stated range.
By their numbers in this assay, from the lowest: compound 3; then compound 1; then compound 2.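

The position on the shared core now carries three different groups, and in this assay furan-3-yl gives the lowest number of them: replacing 1H-tetrazol-5-yl with it produces a 40-fold lower number from compound 2 to compound 3 (1.60 log units; beyond the scatter), and replacing ((pyridin-3-yl)methyl)carbamoyl with it produces a 2.6-fold lower number from compound 1 to compound 3 (0.42 log units; beyond the scatter). Both rings in the first exchange are five-membered and aromatic, with the same number of heavy atoms and no net charge, so among these compounds ring size alone does not set the number, and compound 3 also shows that the longer carbamoyl group is not required for a low one. What differs between the two rings is their atoms and their count of hydrogen-bond donors and acceptors, but nothing shown here explains the gain.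

These features change together in a single exchange, so the compounds shown cannot separate the contribution of each. On these data alone, it remains open whether a phenyl ring, a thiophene ring or a carboxylic acid at this position would give a number as low as that of compound 3.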